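The source may hold more compounds than are shown below. What is called first, only, known or untested is meant among the compounds shown, and "the series" means these compounds.

In a functional assay on MCF7 cells (Homo sapiens) for inhibition, read by CCK-8 assay, with a stated time of 48 h (on this read-out lower numbers stand for stronger inhibition of growth and higher numbers for weaker inhibition of growth), three compounds built on a shared core have been measured. Compound 1 `CN1CCN(c2ccc(Nc3ncc(Cl)c(Nc4ccccc4)n3)nc2)CC1`, which carries a phenyl group, gives 51800 nM. Compound 2 `COc1ccccc1CNc1nc(Nc2ccc(N3CCN(C)CC3)cn2)ncc1Cl` carries 2-methoxybenzyl in its place. The reading for compound 2 is a limit and not a number, > 100000 nM, and the limit of > 100000 nM in this assay, at which 1 of the 3 values shown sits, marks where that limit sits. The step is an at least 1.9-fold higher number from compound 1 to compound 2 (0.28 log units; that floor lies within the scatter). Compound 3 `Cc1ccc(Nc2nc(Nc3ccc(N4CCN(C)CC4)cn3)ncc2Cl)cc1`, with a 4-methylphenyl group, gives 11400 nM, the lowest of the two actual numbers, and it lies beyond the scatter from both other compounds: a 4.5-fold lower number from compound 1 to compound 3 (0.66 log units; beyond the scatter), and an at least 8.7-fold lower number from compound 2 to compound 3 (0.94 log units; beyond the scatter).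

Compound 4 `CN1CCN(c2ccc(Nc3ncc(Cl)c(Nc4ccc(C(C)(C)C)cc4)n3)nc2)CC1` differs from compound 3 in one group: tert-butyl in place of methyl on an aromatic carbon, para to a large group. The nearest guide is the step of a 4.5-fold lower number from compound 1 to compound 3 (0.66 log units; beyond the scatter), where methyl in place of hydrogen on an aromatic carbon came with a modest drop. The step of an at least 8.7-fold lower number from compound 2 to compound 3 (0.94 log units; beyond the scatter) exchanges a whole substituent and says less about this change. With a single close precedent, a small further move towards lower numbers is expected in this assay, possibly no larger than the scatter. The expected step is a 1.8-fold lower number from compound 3 to compound 4 (0.24 log units; within the scatter). The estimate for compound 4 is 6500 nM, with an expected range from 2200 nM to 22000 nM.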

Compound 4, concentration for 50% growth inhibition: 12600 nM
The estimate for compound 4 lay 1.9-fold (0.29 log units) below the measured number; measured number inside the range.
By their numbers in this assay, from the lowest: compounds 3 and 4 (each within the scatter of the next); then compound 1. At a limit, above all of these: compound 2.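

In this assay, among the compounds shown here, moving from methyl to tert-butyl at this place, on an aromatic carbon para to a large group, gives a 1.1-fold higher number from compound 3 to compound 4 (0.04 log units; within the scatter) and so leaves the reading unchanged within the scatter, something the earlier compounds could not show because they carried only hydrogen or methyl here. With a 4.1-fold lower number from compound 1 to compound 4 (0.61 log units; beyond the scatter) set beside a 4.5-fold lower number from compound 1 to compound 3 (0.66 log units; beyond the scatter) the drop from hydrogen is no longer tied to methyl alone, since tert-butyl, a group with more carbon atoms, also stands beyond the scatter from hydrogen. The reading for compound 2 is a limit and not a number, so the step of an at least 7.9-fold lower number from compound 2 to compound 4 (0.89 log units; beyond the scatter) is only a floor, though it places 4-(tert-butyl)phenyl clear of 2-methoxybenzyl, as 4-methylphenyl already was: the limit of > 100000 nM in this assay, at which 1 of the 4 values shown sits.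

From the compounds shown here alone, whether this tolerance holds for groups other than simple alkyl ones, such as an amine, a carboxylic acid, a methoxy group or a chlorine atom at the same place, stays open. Going by these compounds, it also stays open whether a longer chain or a ring there would keep the reading where methyl and tert-butyl put it.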